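Furan-to-thiophene swap on the saturated ring carbon

The compounds below may be only part of what the source reports. "The series", "measured", "known", "first", "only" and "open" are said of these compounds alone.

Measured so far:
compound 1, `NS(=O)(=O)c1ccc(N2N=C(c3ccco3)CC2c2ccco2)cc1`: 383 umol/kg
compound 2, `CS(=O)(=O)c1ccc(N2N=C(C(=O)O)CC2c2ccco2)cc1`: 240 umol/kg

Two compounds of the series have been run in a functional assay on the whole organism with Rattus norvegicus as the target, read by paw edema, in the formalin test, with a stated time of 3 h; a higher number here means that more compound is needed for the effect, a lower number that less compound is needed. Compound 1 gives 383 umol/kg in this assay. Compound 2 gives 240 umol/kg in this assay. Among the measured compounds shown here, compound 1 holds the higher of the two numbers, but the gap to compound 2 lies within the usual scatter of repeated runs, so no order between the two is claimed; compound 2 also differs from compound 1 in more than one place, and no single-change step between measured compounds is available.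

Compound 3, `NS(=O)(=O)c1ccc(N2N=C(c3ccco3)CC2c2cccs2)cc1`, has not yet been measured. Relative to compound 1 the change is thiophen-2-yl in place of furan-2-yl on a saturated ring carbon, with the rest of the structure kept. For the measured compounds named here, no measured pair carries this change, so nothing in the data fixes its direction. The expectation for this assay is a step no larger than the scatter, in either direction. For compound 3 the expected dose is 320 umol/kg, with a range from 160 umol/kg to 650 umol/kg. This estimate corresponds to an expected step of a 1.2-fold lower number from compound 1 to compound 3 (0.08 log units; within the scatter), not beyond the scatter.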

Compound 3, dose for half-maximal effect: 469 umol/kg
Compound 3: the middle estimate sits 1.5-fold (0.17 log units) below what was measured; the range from low to high includes it.
By their numbers in this assay, from the lowest: compounds 2, 1 and 3 (each within the scatter of the next).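

In this assay the series now has its first single-change step, and it belongs to this position: thiophen-2-yl in place of furan-2-yl on a saturated ring carbon gives a 1.2-fold higher number from compound 1 to compound 3 (0.09 log units; within the scatter) and so does not separate compound 3 from compound 1. The earlier compounds shown here could not speak to this position, since compound 2 carries the same furan-2-yl there but differs from compound 1 elsewhere; here, exchanging the oxygen of one five-membered aromatic ring for sulfur, at an equal count of heavy atoms, leaves the two compounds indistinguishable in this read-out, with the rest of the structure kept. No measured property of either group or of the compounds is at hand that could explain this result.

The compounds shown leave open whether a phenyl ring, a longer alkyl chain or an amine on this saturated ring carbon would give a step beyond the scatter. They also leave open whether thiophen-2-yl would read the same way on the ring atom that bears a furan-2-yl group, and whether this swap would read the same way with a carboxylic acid on that ring atom, as in compound 2.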